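The source may report more compounds than this note shows. Statements on the series, on what has been measured and on what is new or still open speak of the compounds shown alone.

Two compounds built on a shared core were examined in an ADME assay on MT4 cells (Homo sapiens) for cytotoxicity, read by MTT assay; a lower number here means that less compound is tolerated, a higher number that more compound is tolerated. Compound 1, with the structure `CCCCCOc1ccc(C(=O)N(C(=S)OCCN2C(=O)c3ccccc3C2=O)c2ccc(F)cc2)cc1`, reaches only a limit of the assay: in this assay compound 1 gives > 100000 nM, which is a limit rather than a measured number. Compound 2, with the structure `Cc1ccc(C(=O)N(C(=S)OCCN2C(=O)c3ccccc3C2=O)c2ccc(Cl)cc2)cc1`, likewise reaches only a limit: in this assay compound 2 gives > 100000 nM. Compound 2 thus stands at the limit of > 100000 nM in this assay, at which 2 of the 2 values shown sit. The next compound, compound 3, has the structure `COc1cccc(OC)c1C(=O)N(C(=S)OCCN1C(=O)c2ccccc2C1=O)c1ccc(Cl)cc1`. It differs from compound 2 in one place: 2,6-dimethoxyphenyl in place of 4-methylphenyl on a carbonyl carbon. For the measured compounds named here, both measured values are limits and no step between them is known, so nothing points to a change beyond the scatter. The step that the limit leaves unreadable from compound 2 to compound 3 is therefore expected to stay within the usual scatter. Compound 3 is estimated at 150000 nM, with a range of 50000 nM to 500000 nM, and is most likely to be reported again only as a limit.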

Compound 3, half-maximal cytotoxic concentration: 69000 nM
Compound 3: middle estimate off by 2.2-fold (0.34 log units), on the high side, and the stated range covers the measured number.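

In this assay, for the compounds shown here, the shared core now gives a real number for the first time: compound 3 gives 69000 nM. The two earlier compounds reached only limits. Placing 2,6-dimethoxyphenyl on the carbonyl carbon in place of 4-methylphenyl gives an at least 1.4-fold lower number from compound 2 to compound 3 (0.16 log units; that floor lies within the scatter), so a change beyond the scatter is neither shown nor ruled out. The true size of the step cannot be read because its starting point is a limit and not a number: the limit of > 100000 nM in this assay, at which 2 of the 3 values shown sit.

Still open, as far as these compounds go, is how this assay would read with a phenyl group carrying an amine or a carboxylic acid on the same carbonyl carbon. The compounds shown also leave open whether a single methoxy group would give a number like that of compound 3.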